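Chain shortening on two dideoxynucleoside cores

The source may report more compounds than this note shows. Statements on the series, on what has been measured and on what is new or still open speak of the compounds shown alone.

Measured so far in a functional assay on Raji cells (Homo sapiens); a higher number here means a weaker inhibitor, a lower number a stronger inhibitor:
compound 1 `CCCCCCc1cn([C@H]2C[C@H](O)[C@@H](CO)O2)c(=O)[nH]c1=O`: 151 ug/mL
compound 3 `CCCCCc1cn([C@H]2C[C@H](O)[C@@H](CO)O2)c(=O)[nH]c1=O`: 334 ug/mL
compound 2 `CCCCCc1cn([C@H]2C[C@@H]3OP(=O)(O)OC[C@H]3O2)c(=O)[nH]c1=O`: a limit only, see below.

In this assay compound 1 gives 151 ug/mL and compound 3 gives 334 ug/mL. Between them stands one change, (hydrogen in place of methyl on a saturated chain carbon, five bonds along the chain from an aromatic carbon), and it made a 2.2-fold higher number from compound 1 to compound 3 (0.34 log units; beyond the scatter). Compound 2 reaches only a limit of the assay, > 500 ug/mL. How the core of compound 2 differs from the core of compound 1 is not broken down here.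

Compound 4 `CCCCc1cn([C@H]2C[C@@H]3OP(=O)(O)OC[C@H]3O2)c(=O)[nH]c1=O` is not yet measured. It arises from compound 2 by hydrogen in place of methyl on a saturated chain carbon, four bonds along the chain from an aromatic carbon, the same kind of change as from compound 1 to compound 3, cut at a chain carbon four bonds along the chain rather than five bonds along.

Since compound 2 already sits at the limit of > 500 ug/mL in this assay, at which 1 of the 3 values shown sits, and the earlier change gave a 2.2-fold higher number from compound 1 to compound 3 (0.34 log units; beyond the scatter), compound 4 is expected to give a still higher number. The expected step is a step that the limit leaves unreadable from compound 2 to compound 4. Compound 4 is estimated at 1000 ug/mL, most probably reported again only as a limit, between 500 ug/mL and 3000 ug/mL.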

Compound 4, concentration for 50% inhibition: 82 ug/mL
Compound 4: the middle estimate sits 12-fold (1.09 log units) above what was measured; the whole stated range lies above it.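

On the core of compound 2, the chain shortening gave an at least 6.0-fold lower number from compound 2 to compound 4 (0.78 log units; beyond the scatter), so the same kind of change did not act alike on the two cores. The two steps run in opposite directions in this assay: the same change on two cores in this assay, a 2.2-fold higher number (0.34 log units; beyond the scatter) from compound 1 to compound 3 and an at least 6.0-fold lower number (0.78 log units; beyond the scatter) from compound 2 to compound 4, at least 13-fold (1.12 log units) apart, beyond the scatter of two such steps. Compound 2 stands at a limit of the assay, > 500 ug/mL, and the cuts lie at different chain carbons, four bonds along the chain on one core and five bonds along on the other, so this shows a difference for these two pairs only and gives neither a cause nor a general rule.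

The compounds shown leave open how the two cores compare at a butyl chain, where only compound 4 is shown. Also open, on these data alone, is how either core responds to a longer chain or to a chain ending in an amine or a carboxylic acid.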